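The compounds below may be only part of what the source reports. "The series", "measured", "known", "first", "only" and "open" are said of these compounds alone.

Measured so far in a functional assay (Mus musculus, strain BALB/C) for inhibition, read by MTT assay, with stated times of 24 h and 72 h; on this read-out higher numbers stand for weaker inhibition and lower numbers for stronger inhibition:
compound 1 `Cc1ccc(C(=O)N/N=C/c2cc(Cl)ccc2O)c(O)c1` gives 1290 nM
compound 2 `Cc1ccc(C(=O)N/N=C/c2cccc(Cl)c2)c(O)c1` gives 24400 nM
compound 3 `Cc1ccc(C(=O)N/N=C/c2cc(Br)ccc2O)c(O)c1` gives 1090 nM

Compound 3 differs from compound 1 by bromo in place of chloro on an aromatic carbon; the step is a 1.2-fold lower number from compound 1 to compound 3 (0.07 log units; within the scatter). Compound 2 differs from compound 1 by hydrogen in place of hydroxy on an aromatic carbon; the step is a 19-fold higher number from compound 1 to compound 2 (1.28 log units; beyond the scatter). Compound 4 `Cc1ccc(C(=O)N/N=C/c2cccc(Br)c2)c(O)c1` is not yet measured and differs from compound 3 by hydrogen in place of hydroxy on an aromatic carbon. The two places are not the same word for word: in compound 1 the site is para to a chloro group, in compound 3 para to a bromo group, so this is the same kind of change, not the same change. A step of about an 18-fold higher number from compound 3 to compound 4 (1.26 log units; beyond the scatter) is expected for compound 4 in this assay, because a 19-fold higher number from compound 1 to compound 2 (1.28 log units; beyond the scatter) was large while the core difference a 1.2-fold lower number from compound 1 to compound 3 (0.07 log units; within the scatter) stayed within the scatter. Compound 4 is therefore estimated at 20000 nM in this assay, with a range from 7000 nM to 55000 nM.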

Compound 4, half-maximal inhibitory concentration: 28300 nM
Estimate against measurement, compound 4: 1.4-fold (0.15 log units) below; the range from low to high includes it.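

Hydrogen in place of hydroxy carries over from the chloro compounds to the bromo compounds in this assay, with a 26-fold higher number from compound 3 to compound 4 (1.41 log units; beyond the scatter) matching the earlier step: the same change on two cores in this assay, a 19-fold higher number (1.28 log units; beyond the scatter) from compound 1 to compound 2 and a 26-fold higher number (1.41 log units; beyond the scatter) from compound 3 to compound 4, 1.4-fold (0.14 log units) apart, within the scatter of two such steps. Bromo in place of chloro stays within the scatter whether or not that hydroxy is present, as a 1.2-fold higher number from compound 2 to compound 4 (0.06 log units; within the scatter) shows alongside the earlier pair: the same change on two cores in this assay, a 1.2-fold lower number (0.07 log units; within the scatter) from compound 1 to compound 3 and a 1.2-fold higher number (0.06 log units; within the scatter) from compound 2 to compound 4, 1.4-fold (0.14 log units) apart, within the scatter of two such steps. This transfer is shown only between two halogen variants of the shared core, so it says nothing about more distant cores or about why losing the hydroxy costs so much.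

The compounds shown leave open whether a methoxy group or an amine in place of the hydroxy would keep the numbers of compound 1 and compound 3. Also open, as far as these compounds go, is whether the same step holds with fluoro or a nitrile in place of the halogen.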